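The source may hold more compounds than are shown below. What is called first, only, known or untested is meant among the compounds shown, and "the series" means these compounds.

Measured so far:
compound 1 `Nc1ccccc1NC(=O)c1ccc(CSC(=S)N2CCN(Cc3ccccc3)CC2)cc1` — 18.1%
compound 2 `Nc1ccccc1NC(=O)c1ccc(CSC(=S)N2CCN(c3ccccc3F)CC2)cc1` — 33.7%
compound 3 `Nc1ccccc1NC(=O)c1ccc(CSC(=S)N2CCN(c3cccnc3)CC2)cc1` — 27.6%

All three share one core and differ only in the group on the amine nitrogen in the ring. In a functional assay on MGC-803 cells (Homo sapiens) for antiproliferative activity, read by CCK-8 assay, with a stated time of 72 h, tested at 2 uM (a higher number here means a stronger effect of the compound at the concentration tested, a lower number a weaker effect), compound 3 holds the second highest of the three numbers. Its gap to the nearest, a number 6.1 percentage points lower from compound 2 to compound 3 (within the scatter), lies within the scatter, and so does its gap to the furthest, a number 9.5 percentage points higher from compound 1 to compound 3 (within the scatter). For the measured compounds named here, the one step that clears the scatter is a number 15.6 percentage points higher from compound 1 to compound 2 (beyond the scatter), a modest rise when an aryl group replaces benzyl.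

Compound 4 `N#Cc1ccc(N2CCN(C(=S)SCc3ccc(C(=O)Nc4ccccc4N)cc3)CC2)cc1` is the next member and has not been measured. The change is 4-cyanophenyl in place of pyridin-3-yl on an amine nitrogen in a ring.

Both earlier aryl-for-benzyl steps point the same way but only one is beyond the scatter, and the aryl-for-aryl step, a number 6.1 percentage points lower from compound 2 to compound 3 (within the scatter), is within it. The present change is again aryl for aryl on the same nitrogen, so no step beyond the scatter is expected in this assay; the estimated shift, a number 2.4 percentage points higher from compound 3 to compound 4 (within the scatter), is small. Compound 4 is therefore expected to give about 30%, with a range from 18% to 45%.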

Compound 4, a percentage reported as inhibition, at one concentration (the size of the read-out at that concentration, not a potency): 34.5%
Beside the measured number, compound 4's estimate is 4.5 percentage points below it; the measured number falls inside the stated range.
By their numbers in this assay, from the lowest: compounds 1, 3, 2 and 4 (each within the scatter of the next, the first and the last beyond it).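

In this assay, 4-cyanophenyl on the amine nitrogen in the ring gives a second aryl group that clears the scatter against benzyl, a number 16.4 percentage points higher from compound 1 to compound 4 (beyond the scatter), alongside a number 15.6 percentage points higher from compound 1 to compound 2 (beyond the scatter), so the gain over benzyl now holds for two aryl groups, while compound 3, with pyridin-3-yl, goes against this pattern with a number 9.5 percentage points higher from compound 1 to compound 3 (within the scatter). For the compounds shown here, the aryl groups themselves do not separate: a number 6.9 percentage points higher from compound 3 to compound 4 (within the scatter) and a number 0.8 percentage points higher from compound 2 to compound 4 (within the scatter) both stay within the scatter, so pyridin-3-yl, 2-fluorophenyl and 4-cyanophenyl cannot be ranked at this position, and the nitrile on the ring brings no step of its own beyond the scatter. Nothing available explains why compound 2 and compound 4 stand apart from compound 1.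

Still open, going by these compounds, is whether a small alkyl group such as methyl, an acyl group such as acetyl, or a phenyl ring bearing a methoxy group or a carboxylic acid on the same nitrogen would move the number beyond the scatter of compound 4. The read-out also comes from a single concentration, so how the potencies of these compounds compare remains open.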